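This account rests on a few compounds, and the source may have more. Where it says the series, first, only, none or still open, it means among the compounds named here.

Measured compounds:
Compound 1 `O=C(Nc1ccccc1[N+](=O)[O-])c1ccc(/N=N\c2c[nH]c3ccccc23)cc1` gives 101000 nM in a functional assay on MCF7 cells (Homo sapiens) for inhibition, read by MTT assay, with a stated time of 72 h; on this read-out higher numbers stand for weaker inhibition and lower numbers for stronger inhibition.
Compound 2 `O=C(Nc1ccccc1F)c1ccc(/N=N\c2c[nH]c3ccccc23)cc1` gives 83800 nM in this assay.

Compound 2 holds the lower of the two numbers, but compound 1 sits within the scatter of it, so the pair cannot be ordered. Compound 3 `Cc1cccc(NC(=O)c2ccc(/N=N\c3c[nH]c4ccccc34)cc2)c1` differs from compound 2 by 3-methylphenyl in place of 2-fluorophenyl on an amide-type nitrogen. Going by the values given here, the one measured step, a 1.2-fold lower number from compound 1 to compound 2 (0.08 log units; within the scatter), also exchanged one substituent for another at the same end of the molecule and stayed within the scatter. Among the compounds with values here, that single step is the only guide, and on it a further exchange of the substituent on the phenyl carried by the amide-type nitrogen is not expected to move the number in this assay beyond the scatter in either direction. Compound 3 is therefore expected to give 80000 nM, with a range of 35000 nM to 180000 nM. The expected step, a 1.0-fold lower number from compound 2 to compound 3 (0.02 log units; within the scatter), stays within the scatter.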

Compound 3, half-maximal inhibitory concentration: 73400 nM
Beside the measured number, compound 3's estimate is 1.1-fold (0.04 log units) above it; the range from low to high includes it.
By their numbers in this assay, from the lowest: compounds 3, 2 and 1 (each within the scatter of the next).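

In this assay a third kind of substituent on the phenyl carried by the amide-type nitrogen gives a 1.1-fold lower number from compound 2 to compound 3 (0.06 log units; within the scatter) and also a 1.4-fold lower number from compound 1 to compound 3 (0.14 log units; within the scatter) so that no two of the three compounds can be ordered. Compounds 1 and 2 differed only in the group at the same numbered ring place, whereas 3-methylphenyl also differs from 2-fluorophenyl and 2-nitrophenyl in the numbered place of its substituent, and even this wider exchange stays within the scatter. Nothing available here offers a reason for this result.

As far as these compounds go, whether an amine or a carboxylic acid on this phenyl, or a longer chain on the amide-type nitrogen in its place, would move the number beyond the scatter remains open. So does the effect of any change to the shared core, which is the same in all three compounds.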